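Phenyl in place of tolyl on the fluorinated cyclopentane sulfonamide series

This account rests on a few compounds, and the source may have more. Where it says the series, first, only, none or still open, it means among the compounds named here.

Measured compounds:
compound 1, `O=C(O)CCC/C=C\C[C@H]1[C@H](F)CC[C@@H]1NS(=O)(=O)c1ccccc1`, 1100 nM
compound 2, `Cc1ccc(S(=O)(=O)N[C@H]2CC[C@@H](F)[C@@H]2CCCCOCC(=O)O)cc1`, 1800 nM
compound 3, `Cc1ccc(S(=O)(=O)N[C@H]2CC[C@@H](F)[C@@H]2C/C=C\CCC(=O)O)cc1`, 1900 nM

All three carry a sulfonamide on the shared core and an acid-terminated chain. In a functional assay on a cell-free system (plasma) for inhibition of thromboxane A2 receptor (Homo sapiens), read by turbidimetry (on this read-out lower numbers stand for stronger inhibition and higher numbers for weaker inhibition), compound 3 gives the highest of the three numbers, though nearest to it compound 2 sits within the scatter, and compound 1 also lies within the scatter of compound 3. Among the compounds with values here, the one comparable step, a 1.1-fold higher number from compound 2 to compound 3 (0.02 log units; within the scatter), is flat.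

Compound 4, `O=C(O)CC/C=C\C[C@H]1[C@H](F)CC[C@@H]1NS(=O)(=O)c1ccccc1`, is yet to be measured in this assay. Against compound 3 the change is hydrogen in place of methyl on an aromatic carbon, the methyl sitting para to the large group; cut one bond further out it reads 4-methylphenyl to phenyl. Within the data shown here, no measured pair varies only this group. Compound 1 does carry the unsubstituted phenyl, but with a longer chain, so its value next to that of compound 3 shows only that both lie within the scatter of each other. The measured step concerns the chain and is within the scatter, so no step beyond the scatter is expected from compound 3 to compound 4, a 1.3-fold lower number from compound 3 to compound 4 (0.10 log units; within the scatter). Compound 4 is therefore expected to give about 1500 nM in this assay, with a range from 700 nM to 3500 nM.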

Compound 4, half-maximal inhibitory concentration: 2000 nM
Compound 4: the middle estimate sits 1.3-fold (0.12 log units) below what was measured; measured number inside the range.
By their numbers in this assay, from the lowest: compounds 1, 2, 3 and 4 (each within the scatter of the next).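

In this assay the change of hydrogen in place of methyl on an aromatic carbon, para to a large group, can now be read on its own, and a 1.1-fold higher number from compound 3 to compound 4 (0.02 log units; within the scatter) shows that 4-methylphenyl and phenyl are not told apart on this chain. Chain length also gains its first single-place reading: with carboxy in place of carboxymethyl, on a saturated chain carbon two bonds along the chain from a double-bonded chain carbon, the step is a 1.8-fold higher number from compound 1 to compound 4 (0.26 log units; within the scatter) and so does not separate the two chains either. No measured evidence bears on why these two steps stay flat.

No single-place step shown so far leaves the scatter, so neither the aromatic position nor the chain has yet been seen to move the number in this series. From the compounds shown here alone, what a chlorine or a methoxy group on that aromatic carbon would do stays open, as does the effect on the number of an amide in place of the carboxylic acid at the chain end.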